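The source may hold more compounds than are shown below. What is called first, only, known or untested is meant among the compounds shown, and "the series" means these compounds.

Of the compounds shown here, two built on a shared core have been tested in a functional assay on HT-29 cells (Homo sapiens) for inhibition, read by MTT assay, with a stated time of 72 h; on this read-out higher numbers stand for weaker inhibition and lower numbers for stronger inhibition. Compound 1 `CN(C)CCn1c(=O)c(=Cc2ccc(F)c(F)c2)s/c1=C1\C(=O)Nc2ccc(F)cc21` gives 3090 nM in this assay. Compound 2 `CN(C)CCn1c(=O)c(=Cc2ccc(O)cc2)s/c1=C1\C(=O)Nc2ccc(Cl)cc21` gives 2460 nM in this assay. Among the numbers shown, compound 2 stands nearest to compound 1, and the gap between them lies within the scatter of repeated measurements, so neither can be called the more potent of the two.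

Compound 3 `CN(C)CCn1c(=O)c(=Cc2ccc(O)cc2)s/c1=C1\C(=O)Nc2ccc(F)cc21` has not yet been measured. It differs from compound 2 in one place: fluoro in place of chloro on an aromatic carbon. For the measured compounds named here, no pair of measured compounds differs in this single way, so the size of the step cannot be read from a measured pair; compound 1 carries fluoro at that place but also differs from compound 2 elsewhere. Since compound 1 with 3090 nM and compound 2 with 2460 nM sit within the scatter of one another, only a small step is expected, none beyond the scatter, with a slight lean toward a higher number. Compound 3 is therefore expected to give 3000 nM in this assay, with a range from 1200 nM to 7500 nM. This expectation amounts to an estimated step of a 1.2-fold higher number from compound 2 to compound 3 (0.09 log units; within the scatter).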

Compound 3, half-maximal inhibitory concentration: 1480 nM
For compound 3 the middle estimate is 2.0-fold (0.31 log units) above the measured one; low and high end bracket the measured number.
By their numbers in this assay, from the lowest: compounds 3, 2 and 1 (each within the scatter of the next, the first and the last beyond it).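

In this assay, the exchange of chloro for fluoro on an aromatic carbon of the six-membered aromatic ring can now be read directly, and the step of a 1.7-fold lower number from compound 2 to compound 3 (0.22 log units; within the scatter) shows that this change at this place does not separate the two compounds. For the compounds shown here, with fluoro held at that place, the change of 3,4-difluorophenyl to 4-hydroxyphenyl on the double-bonded chain carbon gives the first single-place step to pass the scatter, though only modestly: a 2.1-fold lower number from compound 1 to compound 3 (0.32 log units; beyond the scatter). Nothing at hand accounts for either step.

The compounds shown cover only two halogens at the first place, so it stays open whether bromo, methoxy or an amine there would give a number beyond the scatter of compound 3. From the compounds shown here alone, it also stays open whether the step between the two aryl groups would hold with chloro in place of fluoro, and whether a carboxylic acid on that phenyl ring, or a longer chain on the ring nitrogen of the shared core, would move the number in either direction.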